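From 4-Fluorophenyl to 6-Fluoropyridin-3-yl

The source may hold more compounds than are shown below. What is called first, only, known or untested is meant among the compounds shown, and "the series" means these compounds.

Two related compounds have so far been tested in a functional assay on SW480 cells (Homo sapiens) for antiproliferative activity, read by sulforhodamine B assay, with a stated time of 48 h; a lower number here means a stronger inhibitor, a higher number a weaker inhibitor. Compound 1 (`COc1ccc(C(=O)/C=C/c2ccccc2-c2ccc(F)nc2)cc1`) gives 10000 nM, and compound 2 (`COc1ccc(C(=O)/C=C/c2ccccc2-c2ccc(F)cc2)cc1OC`) gives 8300 nM. These two numbers lie within the usual scatter of repeated measurements, so they cannot be ranked. Compound 3 (`COc1ccc(C(=O)/C=C/c2ccccc2-c2ccc(F)nc2)cc1OC`) has not yet been measured. It keeps the rest of compound 2 but carries 6-fluoropyridin-3-yl in place of 4-fluorophenyl on an aromatic carbon. Among the compounds with values here, no measured pair shows this swap alone. Still, compound 1 also carries 6-fluoropyridin-3-yl and gives 10000 nM, so no change beyond the scatter is expected in this assay. The expected size of the change is a 1.1-fold higher number from compound 2 to compound 3 (0.04 log units; within the scatter). The estimate for compound 3 is 9000 nM, with an expected range from 4000 nM to 20000 nM.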

Compound 3, half-maximal inhibitory concentration: 15000 nM
Compound 3: middle estimate off by 1.7-fold (0.22 log units), on the low side; the measured number falls inside the stated range.
By their numbers in this assay, from the lowest: compounds 2, 1 and 3 (each within the scatter of the next).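

In this assay, the first direct test of this swap gives no readable change: 6-fluoropyridin-3-yl in place of 4-fluorophenyl, on an aromatic carbon ortho to a large group, amounts to a 1.8-fold higher number from compound 2 to compound 3 (0.26 log units; within the scatter). The ring nitrogen, which brings one hydrogen-bond acceptor to the count, therefore neither clearly helps nor clearly harms here. Within the data shown here, the same pyridine series also gives a first reading for a second place, where methoxy in place of hydrogen amounts to a 1.5-fold higher number from compound 1 to compound 3 (0.18 log units; within the scatter), so that change cannot be told apart from the scatter either. Nothing available explains these numbers.

From the compounds shown here alone, it remains open whether any group on this aromatic carbon can move the number beyond the scatter, such as a ring bearing an amine or a carboxylic acid. A longer chain, such as ethoxy, in place of the added methoxy is also untested among these compounds.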